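The compounds below may be only part of what the source reports. "The series", "measured", "known", "first", "only" and "open" are said of these compounds alone.

Compounds measured so far in a functional assay on CCRF-CEM cells (Homo sapiens) for cytotoxicity, in the absence of a further agent; a higher number here means a weaker inhibitor, a lower number a stronger inhibitor:
Compound 1, `COC(=O)c1ccc(CN(CCCc2c(N)nc(N)nc2O)c2cc(F)cc(F)c2[N+](=O)[O-])cc1`: > 100000 nM, which is a limit of the assay rather than a number.
Compound 2, `Nc1nc(N)c(CCCNc2cc(F)cc(F)c2[N+](=O)[O-])c(O)n1`: 97000 nM.

Compound 1 therefore stands only at the limit of > 100000 nM in this assay, at which 1 of the 2 values shown sits, so no exact figure is known for it. Within the data shown here, the single measured step, an at least 1.0-fold lower number from compound 1 to compound 2 (0.01 log units; that floor lies within the scatter), lies within the scatter and touches a different part of the molecule. Compound 3, `COC(=O)c1ccc(CN(CCCc2c(N)nc(N)nc2O)c2ccc([N+](=O)[O-])c(F)c2F)cc1`, differs from compound 1 by 2,3-difluoro-4-nitrophenyl in place of 3,5-difluoro-2-nitrophenyl on an amine nitrogen. Among the measured compounds shown here, no measured step bears on this rearrangement of the difluoronitrophenyl group, so no shift beyond the scatter in this assay is expected. Compound 3 is thus estimated at about 100000 nM, within 30000 nM to 300000 nM. The expected step is a number no higher from compound 1 to compound 3 (the limit leaves the size open).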

Compound 3, half-maximal inhibitory concentration: 41000 nM
Compound 3: middle estimate off by 2.4-fold (0.39 log units), on the high side; measured number inside the range.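

Exchanging 3,5-difluoro-2-nitrophenyl for 2,3-difluoro-4-nitrophenyl on an amine nitrogen, with the same atoms joined differently, is the first change shown to move the number in this assay beyond the scatter (an at least 2.4-fold lower number from compound 1 to compound 3 (0.38 log units; beyond the scatter)). This means the arrangement of the groups on this ring matters here, whereas the earlier step stayed within the scatter. The true size remains open, as compound 1 stands at a limit: the limit of > 100000 nM in this assay, at which 1 of the 3 values shown sits.

As far as these compounds go, it remains open whether the change would hold with hydrogen in place of 4-(methoxycarbonyl)benzyl. Also open, from the compounds shown here alone, is what an amine in place of the nitro group would do.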